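The source may hold more compounds than are shown below. What is called first, only, known or untested is meant among the compounds shown, and "the series" means these compounds.

Compound 1, `Nc1nc([SeH])nc2ncccc12`: in a functional assay on MCF7 cells (Homo sapiens) for cytotoxicity, read by MTT assay, with a stated time of 72 h (a higher number here means that more compound is tolerated, a lower number that less compound is tolerated), compound 1 gives > 100000 nM, a limit of the assay rather than a number.
Compound 2, `CCCCC[Se]c1nc(N)c2cccnc2n1`: in this assay compound 2 gives 85000 nM.

Going by the values given here, compound 2 holds the only number in this assay; the other result sits at the limit of > 100000 nM in this assay, at which 1 of the 2 values shown sits. Among the compounds with values here, the one measured step, an at least 1.1-fold lower number from compound 1 to compound 2 (0.07 log units; that floor lies within the scatter), comes from putting pentyl in place of hydrogen on the selenium and is only a floor that lies within the scatter.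

Compound 3, `C[Se]c1nc(N)c2cccnc2n1`, differs from compound 2 by hydrogen in place of butyl on a saturated chain carbon bound to a selenium atom. Within the data shown here, the only step that bears on this change is the one from compound 1 to compound 2, which altered the same selenium substituent and produced no shift beyond the scatter. Shortening the chain from pentyl to methyl therefore gives no measured ground to expect a step in either direction, and compound 3 is expected to sit close to compound 2, at a 1.2-fold higher number from compound 2 to compound 3 (0.07 log units; within the scatter). For compound 3 the estimate in this assay is 100000 nM, within 45000 nM to 220000 nM, with a fair chance that only a limit is reported.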

Compound 3, concentration lethal to 50% of the cells: > 100000 nM
Compound 3: a limit, no number; the forecaster's own chance of this, stated with the estimate: 45%; the middle value sits exactly at the limit.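

In this assay compound 3 gives > 100000 nM, a limit of the assay and not a number, so the short methyl on the selenium yields no measured value here. Putting hydrogen in place of butyl on a saturated chain carbon bound to a selenium atom gives an at least 1.1-fold higher number from compound 2 to compound 3 (0.07 log units; that floor lies within the scatter): this is only a floor, and it shows that the change from pentyl to methyl has no readable effect in either direction so far. The step with methyl in place of hydrogen on the selenium cannot be read, and the comparisons at this position now rest mostly on limits: the limit of > 100000 nM in this assay, at which 2 of the 3 values shown sit.

The compounds shown leave open whether any substituent on the selenium can move the result in this assay beyond the scatter, and whether chain length has any bearing on it at all. A longer chain such as decyl, a benzyl group, or a chain ending in an amine or a carboxylic acid could test this position further, and none of these stands among the compounds shown.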